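The compounds below may be only part of what the source reports. "The series", "measured", "known", "first", "only" and "open" are said of these compounds alone.

Working notes on the series. For the measured compounds named here, in an ADME assay on a cell-free system (plasma, Homo sapiens) for protein binding, compound 1 `CCOc1cc2oc(=O)n(CCC(=O)O)c2cc1Cl` gives 95.8%, and compound 2 `C[C@@H](Oc1cc2onc(CCC(=O)O)c2cc1Cl)c1ccccn1` gives 97.8%; these two values lie within the scatter of each other, so neither compound stands apart on the numbers so far. Going by the values given here, no step between measured compounds is available to set a scale. Compound 3 `O=C(O)CCn1c(=O)oc2cc(OCC3CCC3)c(Cl)cc21` differs from compound 1 by cyclobutyl in place of methyl on a saturated chain carbon bound to an oxygen on an aromatic ring. Among the compounds with values here, with no comparable measured step, the expected step a 2.1-fold lower unbound fraction from compound 1 to compound 3 (0.32 log units; beyond the scatter) is small and toward more binding in this assay. For compound 3 the estimate in this assay is 98%, with a range from 96.3% to 99.2%.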

Compound 3, plasma protein binding: 98.1%
Beside the measured number, compound 3's estimate is 1.1-fold (0.02 log units) (unbound fraction) above it, and the stated range covers the measured number.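

In this assay, for the compounds shown here, the change from ethoxy to cyclobutylmethoxy on the shared core gives a 2.2-fold lower unbound fraction from compound 1 to compound 3 (0.34 log units; beyond the scatter), the first single-place step, and it shows that this position can move plasma protein binding beyond the scatter. The step is toward more binding, although compound 1 is already highly bound. No measurement here accounts for the step. Open, on these data alone, is whether a straight pentyl chain at this place gives a step of the same size as cyclobutyl, and whether an amine on the chain reverses its direction.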